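Propoxy to methoxy: one step in a two-compound series

The source may report more compounds than this note shows. Statements on the series, on what has been measured and on what is new or still open speak of the compounds shown alone.

Measured so far:
compound 1 `Cn1c(Cc2nn(C)c(=O)c3ccccc23)nnc1SCCCCCCCCCCC(=O)Nc1ccc(Cl)cc1` — 20000 nM
compound 2 `CCCOc1ccc(NC(=O)CCCCCCCSc2nnc(Cc3nn(C)c(=O)c4ccccc34)n2C)cc1` — 1600 nM

In an assay on isolated protein (Mus musculus) for inhibition of IL15-IL15 receptor (Homo sapiens), read by resazurin assay, with stated times of 30 min and 2.5 days (a lower number here means a stronger inhibitor, a higher number a weaker inhibitor), compound 1 gives 20000 nM and compound 2 gives 1600 nM. Compound 2 stands lowest of the two numbers; its nearest neighbour, compound 1, sits at a higher value, a gap beyond the scatter. Compound 3 `COc1ccc(NC(=O)CCCCCCCSc2nnc(Cc3nn(C)c(=O)c4ccccc34)n2C)cc1` differs from compound 2 by hydrogen in place of ethyl on a saturated chain carbon bound to an oxygen on an aromatic ring. For the measured compounds named here, no step between measured compounds covers such a change, so nothing measured bears on its size. A small loss is expected, a 1.6-fold higher number from compound 2 to compound 3 (0.19 log units; within the scatter), at or just beyond the scatter. Compound 3 is therefore estimated at 2500 nM, with a range from 800 nM to 8000 nM.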

Compound 3, half-maximal inhibitory concentration: 3900 nM
For compound 3 the middle estimate is 1.6-fold (0.19 log units) below the measured one, within the range that was stated.
By their numbers in this assay, from the lowest: compound 2; then compound 3; then compound 1.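

In this assay, for the compounds shown here, propoxy to methoxy gives a 2.4-fold higher number from compound 2 to compound 3 (0.39 log units; beyond the scatter) and is the first step that changes one place only. The ethyl removed therefore counts at this position, although the loss is modest and compound 3 still gives a measured number. No data at hand account for the size of this step. Two points at this position define no trend with chain length. From the compounds shown here alone, whether a longer chain such as butoxy, or a hydroxyl or an amine in place of the ether, would lower or raise the number remains open.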